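The source may hold more compounds than are shown below. What is called first, only, known or untested is meant among the compounds shown, and "the series" means these compounds.

Working notes on the amide series. All three measured compounds share one core and differ only on the amide-type nitrogen: compound 1 `CCn1c(C(=O)N[C@@H](CC(=O)OC)C(=O)OC)ccc1C(CC)(CC)c1ccc(OCS(=O)(=O)c2ccccc2)c(C)c1` carries a 1,2-bis(methoxycarbonyl)ethyl group, compound 2 `CCn1c(C(=O)NC(C)(C)CO)ccc1C(CC)(CC)c1ccc(OCS(=O)(=O)c2ccccc2)c(C)c1` a 1-(hydroxymethyl)-1-methylethyl group, and compound 3 `CCn1c(C(=O)N[C@H](CO)C(C)C)ccc1C(CC)(CC)c1ccc(OCS(=O)(=O)c2ccccc2)c(C)c1` a 1-(hydroxymethyl)-2-methylpropyl group. In a functional assay on BXPC-3 cells (Homo sapiens) for antiproliferative activity, read by MTT assay, with a stated time of 24 h (a higher number here means a weaker inhibitor, a lower number a stronger inhibitor), compound 1 gives only a limit, > 50000 nM. In this assay compound 2 gives 18300 nM and compound 3 gives 7720 nM. The steps read an at least 2.7-fold lower number from compound 1 to compound 2 (0.43 log units; beyond the scatter) and an at least 6.4-fold lower number from compound 1 to compound 3 (0.81 log units; beyond the scatter), both set against (the limit of > 50000 nM in this assay, at which 1 of the 3 values shown sits), and a 2.4-fold lower number from compound 2 to compound 3 (0.37 log units; beyond the scatter). Compound 3 thus holds the lowest number of the two that are numbers, with compound 2 nearest.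

Compound 4 `CCn1c(C(=O)NC2(C(=O)O)CC2)ccc1C(CC)(CC)c1ccc(OCS(=O)(=O)c2ccccc2)c(C)c1` differs from compound 3 in one place: 1-carboxycyclopropyl in place of 1-(hydroxymethyl)-2-methylpropyl on an amide-type nitrogen. Among the measured compounds shown here, no measured step exchanges a hydroxymethyl-bearing group for a carboxy-bearing one; the measured steps move only between the two hydroxymethyl groups or away from the diester of compound 1, and all of them are modest in size. For the measured compounds named here, with no matching step to lean on, the expected step is taken as small, a 1.9-fold higher number from compound 3 to compound 4 (0.29 log units; within the scatter), towards a somewhat higher number. Compound 4 is therefore expected to give about 15000 nM in this assay, within 5000 nM to 50000 nM.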

Compound 4, half-maximal inhibitory concentration: > 50000 nM
Compound 4 ended at the assay's limit; the forecaster's own chance of this, stated with the estimate: 25%; at least 3.3-fold (0.52 log units) between middle value and limit.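

Among the compounds shown here, the change at the amide-type nitrogen from a hydroxymethyl-bearing group to 1-carboxycyclopropyl is a clear loss in this assay, reading an at least 6.4-fold higher number from compound 3 to compound 4 (0.81 log units; beyond the scatter) and an at least 2.7-fold higher number from compound 2 to compound 4 (0.43 log units; beyond the scatter), whereas the earlier steps between the two hydroxymethyl groups showed only a modest difference. Across the four compounds, only the 1-(hydroxymethyl)-1-methylethyl and 1-(hydroxymethyl)-2-methylpropyl groups give numbers, and no compound shown goes against this. The carboxy-bearing compound 4 and the diester compound 1 both end at a limit rather than a number, so the step between them cannot be read: the limit of > 50000 nM in this assay, at which 2 of the 4 values shown sit.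

The 1-carboxycyclopropyl group brings in the carboxylic acid and the three-membered ring together, and the compounds shown do not separate the two, which a 1-(hydroxymethyl)cyclopropyl or a 1-carboxy-2-methylpropyl group on the same nitrogen would do. Also open, from the compounds shown here alone, are how far past the limit compound 4 lies and whether a methyl ester of the same 1-carboxycyclopropyl group, or an amine in place of its carboxylic acid, would return a number.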